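Replacing the cyanosulfanyl group with an ethylcarbamoyl group

The source may report more compounds than this note shows. Statements on the series, on what has been measured and on what is new or still open speak of the compounds shown alone.

Measured compounds:
compound 1 `N#CCCCc1c[nH]c2ccc(F)cc12`, 63 nM
compound 2 `NCCCCc1c[nH]c2c(F)cccc12`, 6 nM
compound 3 `N#CSCCCc1c[nH]c2ccc(F)cc12`, 5 nM

In an assay on isolated protein (urine) for inhibition of Myeloperoxidase (Homo sapiens), with a stated time of 5 min (on this read-out higher numbers stand for weaker inhibition and lower numbers for stronger inhibition), compound 3 gives the lowest number of the three; its nearest neighbour is compound 2, within the scatter, while compound 1 lies well beyond it. Compound 4 `CCNC(=O)CCCc1c[nH]c2ccc(F)cc12` differs from compound 3 by ethylcarbamoyl in place of cyanosulfanyl on a saturated chain carbon, three bonds along the chain from an aromatic carbon. Going by the values given here, the only measured step bearing on this position is a 13-fold lower number from compound 1 to compound 3 (1.10 log units; beyond the scatter), which shows that the cyanosulfanyl group carries a large part of the potency of compound 3. Since compound 4 gives up that group for an ethylcarbamoyl group, a step back toward weaker inhibition is expected, of the order of a 20-fold higher number from compound 3 to compound 4 (1.30 log units; beyond the scatter). Compound 4 is therefore estimated at 100 nM in this assay, within a range from 20 nM to 500 nM.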

Compound 4, half-maximal inhibitory concentration: 182 nM
Compound 4: middle estimate off by 1.8-fold (0.26 log units), on the low side, within the range that was stated.
By their numbers in this assay, from the lowest: compounds 3 and 2 (each within the scatter of the next); then compound 1; then compound 4.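

In this assay the ethylcarbamoyl group loses the gain that came with the cyanosulfanyl group (a 36-fold higher number from compound 3 to compound 4 (1.56 log units; beyond the scatter)) and also ends up behind the plain cyano group (a 2.9-fold higher number from compound 1 to compound 4 (0.46 log units; beyond the scatter)). The end of the chain at this position therefore does more than tolerate change: the three groups compared give clearly separate results, and the amide is the poorest of them. Nothing available explains this drop. As far as these compounds go, whether a primary carboxamide or a carboxylic acid would fare better here remains open. So does whether a methylthio group would keep the potency of compound 3.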